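One Methoxy Less: Expected Growth Inhibition of Compound 4

The source may report more compounds than this note shows. Statements on the series, on what has been measured and on what is new or still open speak of the compounds shown alone.

The measured compounds, with their values in a functional assay on LOX IMVI cells (Homo sapiens) for inhibition, read by sulforhodamine B assay, with a stated time of 48 h; a higher number here means a weaker inhibitor of growth, a lower number a stronger inhibitor of growth:
compound 1, `COc1cc(-c2cc(/C=C/C(=O)c3ccc(N)cc3)[nH]n2)cc(OC)c1OC`, gives 3280 nM
compound 2, `COc1ccc(-c2cc(/C=C/C(=O)c3ccc(N)cc3)[nH]n2)cc1OC`, gives 3910 nM
compound 3, `COc1cc(C(=O)/C=C/c2cc(-c3cc(OC)c(OC)c(OC)c3)n[nH]2)cc(OC)c1OC`, gives 2910 nM

The three values lie close together; every gap between them is within the usual scatter, so none of the three can be called stronger or weaker than another. Compound 3 stands at the low end of the set, and its nearest neighbour is compound 1, which is within the scatter of it. The difference between the core of compound 1 and the core of compound 3 is not broken down here.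

Compound 1 and compound 2 differ by hydrogen in place of methoxy on an aromatic carbon. That change gave a 1.2-fold higher number from compound 1 to compound 2 (0.08 log units; within the scatter).

Compound 4, `COc1ccc(-c2cc(/C=C/C(=O)c3cc(OC)c(OC)c(OC)c3)[nH]n2)cc1OC`, has not yet been measured in this assay. It differs from compound 3 by hydrogen in place of methoxy on an aromatic carbon, the same change that leads from compound 1 to compound 2. Resting on that earlier step, compound 4 is expected to show a 1.2-fold higher number from compound 3 to compound 4 (0.08 log units; within the scatter). The estimate for compound 4 in this assay is 3500 nM, expected to fall between 1800 nM and 7000 nM.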

Compound 4, concentration for total growth inhibition: 2880 nM
Compound 4: the middle estimate sits 1.2-fold (0.08 log units) above what was measured; low and high end bracket the measured number.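

In this assay, hydrogen in place of methoxy on an aromatic carbon gave a 1.0-fold lower number from compound 3 to compound 4 (0.00 log units; within the scatter). Set beside the earlier step, the same change reads alike on the two cores: the same change on two cores in this assay, a 1.2-fold higher number (0.08 log units; within the scatter) from compound 1 to compound 2 and a 1.0-fold lower number (0.00 log units; within the scatter) from compound 3 to compound 4, 1.2-fold (0.08 log units) apart, within the scatter of two such steps This shows that, on both cores, the change left the number within the scatter, so in this pair of cores it carried over as a step too small to read; it does not show that the methoxy group has no influence at all, as steps of this size cannot separate a small real shift from none, and two cores say nothing firm about any further core in the series.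

The compounds shown leave open what a different group in the same place, such as a hydroxyl group, a chlorine atom or a longer chain like ethoxy, would do to the number. They also leave open whether taking away more than one methoxy group would stay as quiet as taking away one.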